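This account rests on a few compounds, and the source may have more. Where it says the series, first, only, none or still open, it means among the compounds named here.

Measured so far in an ADME assay on microsomes from liver (Homo sapiens) for metabolic stability, read by LC-MS, using NADPH, with stated times of 5 min and 30 min, tested at 1 uM; a higher number here means faster removal of the compound, a lower number slower removal:
- compound 1 `Fc1ccc2c(c1CNc1ncc(Oc3ccccc3)c3nncn13)CCO2`: 18 mL.min-1.g-1
- compound 2 `CN(c1ccccc1)c1cnc(NCc2c(F)ccc3c2CCO3)n2cnnc12`: 55 mL.min-1.g-1

Compound 2, at 55 mL.min-1.g-1, holds the higher of the two numbers in this assay, and its gap to compound 1 lies beyond the scatter. Next in line is compound 3 `CN(c1ccn(C)n1)c1cnc(NCc2c(F)ccc3c2CCO3)n2cnnc12`. The structural change is 1-methyl-1H-pyrazol-3-yl in place of phenyl on a nitrogen on an aromatic ring, which in words is 1-methyl-1H-pyrazol-3-yl in place of phenyl on a nitrogen on an aromatic ring, so methyl(phenyl)amino becomes methyl(1-methyl-1H-pyrazol-3-yl)amino.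

Within the data shown here, only one measured step bears on this, and only loosely: a 3.1-fold higher number from compound 1 to compound 2 (0.49 log units; beyond the scatter), a modest step that put methyl(phenyl)amino in place of phenoxy. That step keeps the phenyl and so does not test its exchange. Among the measured compounds shown here, no measured pair covers the new ring, which leaves the direction a judgement, with a modest fall expected and no change still open. For the measured compounds named here, the expected shift is a 2.0-fold lower number from compound 2 to compound 3 (0.29 log units; within the scatter), with a size borrowed from the one known step. The estimate for compound 3 is 28 mL.min-1.g-1, with an expected range of 12 mL.min-1.g-1 to 60 mL.min-1.g-1.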

Compound 3, intrinsic clearance in microsomes: 11 mL.min-1.g-1
The estimate for compound 3 lay 2.5-fold (0.41 log units) above the measured number, outside the stated range (below it).
By their numbers in this assay, from the lowest: compounds 3 and 1 (each within the scatter of the next); then compound 2.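

In this assay, the group on this nitrogen on an aromatic ring matters in its own right: 1-methyl-1H-pyrazol-3-yl in place of phenyl gives a 5.0-fold lower number from compound 2 to compound 3 (0.70 log units; beyond the scatter), an exchange the earlier pair, both carrying phenyl, could not test. Methyl(1-methyl-1H-pyrazol-3-yl)amino in place of phenoxy gives a 1.6-fold lower number from compound 1 to compound 3 (0.21 log units; within the scatter), so the earlier 3.1-fold higher number from compound 1 to compound 2 (0.49 log units; beyond the scatter) does not hold for every group on the amino nitrogen, and with the new ring the amino-linked compound 3 stays within the scatter of the phenoxy compound 1. Nothing available gives a reason for either step.

Still open, as far as these compounds go, is whether the fall belongs to the pyrazole ring itself or to the methyl on it, which an unsubstituted 1H-pyrazol-3-yl or a pyridin-2-yl on the same nitrogen would help to separate. Also open, from the compounds shown here alone, are whether the methyl on the amino nitrogen contributes to the reading, as a hydrogen or an ethyl there would show, and whether a 1-methyl-1H-pyrazol-3-yl joined through oxygen would differ from compound 1.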